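Chlorine removal on a sulfonamide series in breast cancer cells

This account rests on a few compounds, and the source may have more. Where it says the series, first, only, none or still open, it means among the compounds named here.

The study covers four sulfonamides that share a core and differ in the substitution on their aromatic rings. Compound 1 `COc1cc(N(Cc2nc3ccccc3[nH]2)S(=O)(=O)c2ccccc2)cc(OC)c1OC` gives 27300 nM in a functional assay on MCF7 cells (Homo sapiens) for inhibition, read by MTT assay, with a stated time of 48 h; a higher number here means a weaker inhibitor, a lower number a stronger inhibitor. Compound 2 `COc1cc(N(Cc2nc3ccccc3[nH]2)S(=O)(=O)c2ccccc2Cl)cc(OC)c1OC`, which carries a chloro group, gives 38100 nM in this assay. Compound 3 `Cc1ccc(S(=O)(=O)N(Cc2nc3ccccc3[nH]2)c2ccc(Cl)cc2)cc1` gives 38300 nM in this assay, and the difference between the core of compound 3 and the core of compound 2 is not broken down here. Compound 4 `Cc1ccc(S(=O)(=O)N(Cc2nc3ccccc3[nH]2)c2ccccc2)cc1` has not yet been measured.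

The change from compound 2 to compound 1 is hydrogen in place of chloro on an aromatic carbon, and it gave a 1.4-fold lower number from compound 2 to compound 1 (0.14 log units; within the scatter). The change from compound 3 to compound 4 is hydrogen in place of chloro on an aromatic carbon. The two are the same kind of change, but they do not sit in the same surroundings: in the pair of compound 2 and compound 1 the chloro leaves a carbon ortho to a large group, whereas in the pair of compound 3 and compound 4 it leaves a carbon para to a large group.

Since the earlier step stayed within the scatter, compound 4 is expected to show a 1.3-fold lower number from compound 3 to compound 4 (0.11 log units; within the scatter) in this assay, a step of about the same small size, resting on compound 3 and its value 38300 nM. The estimate for compound 4 in this assay is therefore 30000 nM, with a range from 12000 nM to 75000 nM.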

Compound 4, half-maximal inhibitory concentration: 49700 nM
Beside the measured number, compound 4's estimate is 1.7-fold (0.22 log units) below it; the range from low to high includes it.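

In this assay, within the data shown here, hydrogen in place of chloro on the second core gives a 1.3-fold higher number from compound 3 to compound 4 (0.11 log units; within the scatter), so on this core, as on the first, the change leaves a step that repeated measurements could not tell from no step at all. The two steps carry opposite signs on paper, but that gap is itself no larger than measurement noise allows, and the two pairs give no sign that the change acts differently from one core to the other: the same change on two cores in this assay, a 1.4-fold lower number (0.14 log units; within the scatter) from compound 2 to compound 1 and a 1.3-fold higher number (0.11 log units; within the scatter) from compound 3 to compound 4, 1.8-fold (0.26 log units) apart, within the scatter of two such steps

Among these compounds, this shows only that the change produced no readable step on either core, and it does not show that a shared effect carries across them: with both steps this small, the pairs cannot say whether the chloro group matters at all in these surroundings, nor whether its place on the ring makes any difference.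

The compounds shown leave open whether a group of another kind on the same aromatic carbon, such as an amine, a carboxylic acid or a longer alkyl chain, would produce a step beyond the scatter. They also leave open whether a change of this kind would read the same way in cells other than those used here.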